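Cyclohexyl Amide in Place of the Oxane Side Chain

The compounds below may be only part of what the source reports. "The series", "measured", "known", "first", "only" and "open" are said of these compounds alone.

Compound 3 `N#Cc1cnc(NCc2cnccc2C(F)(F)F)cc1NCC1CCOCC1` holds the lower of the two numbers found in an assay on isolated protein for inhibition of protein kinase C delta type (Homo sapiens), read by TR-FRET, with a stated time of 2 h (a higher number here means a weaker inhibitor, a lower number a stronger inhibitor), giving 5000 nM. Compound 2 `N#Cc1cnc(NCc2cnccc2C(F)(F)F)cc1NC1CCOCC1` gives 9800 nM, so that a 2.0-fold lower number from compound 2 to compound 3 (0.29 log units; within the scatter). Compound 1 `N#Cc1cnc(NCc2cnccc2C(F)(F)F)cc1N[C@H]1C[C@H](O)C1` gives only a limit, > 10000 nM, and (the limit of > 10000 nM in this assay, at which 1 of the 3 values shown sits). Compound 4 `CNC(=O)[C@H]1CC[C@@H](Nc2cc(NCc3cnccc3C(F)(F)F)ncc2C#N)CC1` has not been measured; it differs from compound 3 by 4-(methylcarbamoyl)cyclohexyl in place of (oxan-4-yl)methyl on a nitrogen on an aromatic ring. Among the compounds with values here, the one fully numbered step, a 2.0-fold lower number from compound 2 to compound 3 (0.29 log units; within the scatter), swapped a ring for a ring plus one carbon and stayed within the scatter, while an at least 1.0-fold lower number from compound 1 to compound 2 (0.00 log units; that floor lies within the scatter) and an at least 2.0-fold lower number from compound 1 to compound 3 (0.30 log units; that floor lies within the scatter) rest on a limit. Within the data shown here, no measured step introduces an amide, so no step beyond the scatter is expected. Compound 4 is therefore estimated at 4500 nM, between 1200 nM and 15000 nM. The expected step is a 1.1-fold lower number from compound 3 to compound 4 (0.05 log units; within the scatter).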

Compound 4, half-maximal inhibitory concentration: 1600 nM
Beside the measured number, compound 4's estimate is 2.8-fold (0.45 log units) above it, within the range that was stated.
By their numbers in this assay, from the lowest: compound 4; then compounds 3 and 2 (each within the scatter of the next). At a limit, above all of these: compound 1.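

Only with 4-(methylcarbamoyl)cyclohexyl on this nitrogen do steps in this assay pass the scatter: a 3.1-fold lower number from compound 3 to compound 4 (0.49 log units; beyond the scatter) and a 6.1-fold lower number from compound 2 to compound 4 (0.79 log units; beyond the scatter). The side chain at this position can therefore move the number measurably, although the change remains modest. Compound 1 gives only a limit, which makes an at least 6.2-fold lower number from compound 1 to compound 4 (0.79 log units; beyond the scatter) a floor: the limit of > 10000 nM in this assay, at which 1 of the 4 values shown sits.

The change brings in a carbon-only ring and an amide together, so the share of each cannot be separated. On these data alone, how a carboxylic acid or an amine in place of the methylcarbamoyl group would read also stays open.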